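This account rests on a few compounds, and the source may have more. Where it says the series, first, only, none or still open, it means among the compounds named here.

Of the compounds shown here, three built on a shared core have been tested in an assay on CHO-K1 cells for displacement of a labelled ligand from melanin-concentrating hormone receptor 1 (Homo sapiens), read by scintillation proximity assay, with a stated time of 2 h; a higher number here means a weaker inhibitor, a lower number a stronger inhibitor. Compound 1 `C/C(=C\C(=O)Nc1ccc2nc(N3CCC(O)CC3)nc(C)c2c1)c1ccc(Cl)cc1` gives 670 nM. Compound 2 `Cc1nc(N2CCC(N3CCOC3=O)CC2)nc2ccc(NC(=O)/C=C/c3ccc(OC(F)(F)F)cc3)cc12` gives 41 nM, and compound 3 `Cc1nc(NCCNC(=O)C2CC2)nc2ccc(NC(=O)/C=C/c3ccc(OC(F)(F)F)cc3)cc12` gives 61 nM. Compound 3 therefore stands second highest of the three numbers, close to compound 2 and far from compound 1. Compound 4 `Cc1nc(N2CCC(N3CCNC3=O)CC2)nc2ccc(NC(=O)/C=C/c3ccc(OC(F)(F)F)cc3)cc12` differs from compound 3 by 4-(2-oxoimidazolidin-1-yl)piperidin-1-yl in place of (2-((cyclopropylcarbonyl)amino)ethyl)amino on an aromatic carbon. Of the measured steps, only a 1.5-fold higher number from compound 2 to compound 3 (0.17 log units; within the scatter) bears on this change: there the same (2-((cyclopropylcarbonyl)amino)ethyl)amino group replaced a 4-(2-oxo-1,3-oxazolidin-3-yl)piperidin-1-yl group, which is closely related to the entering 4-(2-oxoimidazolidin-1-yl)piperidin-1-yl group, and that step stayed within the scatter. Reversing a step of that kind is expected to give compound 4 a change of about a 1.4-fold lower number from compound 3 to compound 4 (0.13 log units; within the scatter) in this assay, which would not exceed the scatter. Compound 4 is accordingly estimated at 45 nM, with a range from 20 nM to 100 nM.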

Compound 4, half-maximal inhibitory concentration: 66 nM
Beside the measured number, compound 4's estimate is 1.5-fold (0.17 log units) below it; low and high end bracket the measured number.
By their numbers in this assay, from the lowest: compounds 2, 3 and 4 (each within the scatter of the next); then compound 1.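

In this assay, a third group on the aromatic carbon between two ring nitrogen atoms leaves the number unresolved from the first two: the exchange of the open chain for the 4-(2-oxoimidazolidin-1-yl)piperidin-1-yl group gives a 1.1-fold higher number from compound 3 to compound 4 (0.03 log units; within the scatter) and no separation. The smaller change inside the piperidine substituent, 2-oxoimidazolidin-1-yl in place of 2-oxo-1,3-oxazolidin-3-yl on a saturated ring carbon, gives a 1.6-fold higher number from compound 2 to compound 4 (0.21 log units; within the scatter) and also no separation, so compounds 2, 3 and 4 cannot be ranked. Nothing given here accounts for these results. As far as these compounds go, whether a carboxylic acid or a primary amine at this position would stay within the scatter of these three remains open. Compound 1 differs from each of them in more than one place, so its relation to them also stays unresolved.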